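The compounds below may be only part of what the source reports. "The series", "measured", "known", "first", "only" and "open" are said of these compounds alone.

Three compounds already have numbers in an assay on isolated protein for binding affinity to serine protease 1 (Homo sapiens); on this read-out lower numbers stand for stronger inhibition and higher numbers for weaker inhibition. Compound 1 `N=C(N)c1cccc(C(=O)NC(C(=O)NCC2CCC(CN)CC2)c2cccc3ccccc23)c1` gives 2100 nM in this assay. Compound 2 `N=C(N)c1cccc(C(=O)N[C@@H](C(=O)N2CCN(C(=O)c3ccccc3)CC2)c2ccccc2)c1` carries a different amide portion and gives 460 nM, so compound 1 stands at the higher of the two single numbers. Compound 3 `N=C(N)c1cccc(C(=O)NC(C(=O)NCC2CCC(CN)CC2)c2cccc(Cl)c2)c1` keeps the rest of compound 1 but bears a single chlorine-bearing ring in place of the two-ring group, and across its repeated entries the several entries of compound 3 in this assay, 5100 nM; 3900 nM (2 entries) compound 3 gives 5100 nM; 3900 nM (2 entries).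

Compound 4 `N=C(N)c1cccc(C(=O)NC(C(=O)NCC2CCC(CN)CC2)c2ccc(Cl)cc2)c1` has no number yet. It differs from compound 1 in one place: 4-chlorophenyl in place of naphthalen-1-yl on a saturated chain carbon bound to an amide-type nitrogen and a carbonyl carbon. Among the measured compounds shown here, no step between two measured compounds matches this change exactly. The closest guide is compound 3, which also puts a chlorine-bearing single ring at that place and gives 5100 nM; 3900 nM (2 entries), weaker than compound 1. The step of a 1.7-fold higher number from compound 1 to compound 4 (0.22 log units; within the scatter) is therefore expected to run toward weaker binding, by a modest amount near the edge of the scatter. Compound 4 is estimated at 3500 nM, with a range from 1500 nM to 8000 nM.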

Compound 4, inhibition constant: 6000 nM
Beside the measured number, compound 4's estimate is 1.7-fold (0.23 log units) below it, and the stated range covers the measured number.
By their numbers in this assay, from the lowest: compound 2; then compound 1; then compound 4.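

In this assay, putting 4-chlorophenyl in place of naphthalen-1-yl gives a 2.9-fold higher number from compound 1 to compound 4 (0.46 log units; beyond the scatter), so the group on this saturated chain carbon affects binding by more than the usual scatter. This one change both removes an aromatic ring and adds a chlorine, and the step alone cannot separate these two parts. Compound 3 also carries a chlorine-bearing single ring at this place, and its numbers likewise stand above that of compound 1: the several entries of compound 3 in this assay, 5100 nM; 3900 nM (2 entries)

Still open, on these data alone, is whether the second aromatic ring of naphthalen-1-yl or the chlorine accounts for the step. As far as these compounds go, how a single ring carrying an amine or a carboxylic acid in place of the chlorine would read at this place also remains unknown.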